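This account rests on a few compounds, and the source may have more. Where it says the series, first, only, none or still open, it means among the compounds named here.

Going by the values given here, compound 1, with the structure `COc1cc(OC)c(/C=C(\C(=O)c2ccc(Br)cc2)S(=O)(=O)Cc2ccc(Cl)cc2)c(OC)c1`, is one of three compounds measured in a functional assay on DU-145 cells (Homo sapiens) for inhibition, read by trypan blue exclusion, with a stated time of 96 h (a lower number here means a stronger inhibitor of growth, a higher number a weaker inhibitor of growth), where compound 1 gives 25000 nM. Compound 2, `CSc1ccc(/C=C(\C(=O)c2ccc(Br)cc2)S(=O)(=O)Cc2ccc(C)cc2)cc1`, gives 10000 nM in this assay, and compound 3, `COc1cc(OC)c(/C=C(\C(=O)c2ccc([N+](=O)[O-])cc2)S(=O)(=O)Cc2ccc(Cl)cc2)c(OC)c1`, gives 10000 nM. Compound 1 therefore stands with the highest number of the three, and the step of a 2.5-fold lower number from compound 1 to compound 3 (0.40 log units; beyond the scatter) is a modest one.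

Compound 4, `COc1cc(OC)c(/C=C(\C(=O)c2ccc(Br)cc2)S(=O)(=O)c2ccc(C)cc2)c(OC)c1`, differs from compound 1 in one place: 4-methylphenyl in place of 4-chlorobenzyl on a sulfonyl sulfur. Among the compounds with values here, none of the measured steps bears on this change. Within the data shown here, the single step from compound 1 to compound 3 concerns a different position, and compound 2 differs from compound 1 in more than one place, so its value cannot be read as a step. Among the measured compounds shown here, with no measured step touching the sulfonyl sulfur, there is no ground to expect a change in this assay beyond the usual scatter in either direction, and any estimate must carry a wide range.

Compound 4 is therefore expected to give about 25000 nM in this assay, between 8000 nM and 80000 nM, which means an expected step of no change at the digits printed from compound 1 to compound 4 (within the scatter).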

Compound 4, concentration for 50% growth inhibition: > 100000 nM
Compound 4 ended at the assay's limit; the forecaster's own chance of this, stated with the estimate: 10%; at least 4.0-fold (0.60 log units) between middle value and limit.
By their numbers in this assay, from the lowest: compounds 2 and 3 (each within the scatter of the next); then compound 1. At a limit, above all of these: compound 4.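

The sulfonyl sulfur proves to be a place where a single change counts in this assay: 4-methylphenyl in place of 4-chlorobenzyl gives an at least 4.0-fold higher number from compound 1 to compound 4 (0.60 log units; beyond the scatter). Going by these compounds alone, the earlier compounds could not show this, since the only single-place step among them lay elsewhere on the core. For compound 4 the reading is a limit of the assay and not a number, so only the least size of the step is known: the limit of > 100000 nM in this assay, at which 1 of the 4 values shown sits.

This one pair changes the benzyl carbon and the chlorine together, which leaves open which of the two carries the step, and 4-methylbenzyl or 4-chlorophenyl on the sulfonyl sulfur would separate them. Also open, as far as these compounds go, is whether a longer chain, such as 2-phenylethyl, or an amine-bearing benzyl group at this place would keep the number near that of compound 1.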